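From an Ester Side Chain to a Nitro Group

The compounds below may be only part of what the source reports. "The series", "measured", "known", "first", "only" and "open" are said of these compounds alone.

Compound 1, `CC(=O)OCc1ccc2oc(=O)c(C(=O)Sc3cccc(Cl)c3)cc2c1`, gives 65.8% in a functional assay on HT-1080 cells (Homo sapiens), read by transwell migration, with a stated time of 24 h, tested at 1 uM; on this read-out higher numbers stand for a weaker effect at the one concentration tested and lower numbers for a stronger effect.
Compound 2, `CCCCC(=O)OCc1ccc2oc(=O)c(C(=O)Oc3cccc(Br)c3)cc2c1`, gives 63.3% in this assay.

Compound 2 holds the lower of the two numbers, yet compound 1 lies only slightly higher, within the scatter, so the two cannot be told apart. Compound 3, `O=C(Oc1cccc(Br)c1)c1cc2cc([N+](=O)[O-])ccc2oc1=O`, has not yet been measured. It differs from compound 2 in one place: nitro in place of ((butylcarbonyl)oxy)methyl on an aromatic carbon. Among the measured compounds shown here, no pair of measured compounds differs in a single place, so there is no measured step to lean on, and the two numbers themselves give no hint of direction. The expectation is therefore a modest step from compound 2 to compound 3 of a number 4.7 percentage points higher from compound 2 to compound 3 (within the scatter) in this assay, with no change beyond the scatter the most likely outcome. Compound 3 is estimated at 68%, within a range from 50% to 86%.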

Compound 3, a percentage reported as activity, at one concentration (the size of the read-out at that concentration, not a potency): 35.2%
Beside the measured number, compound 3's estimate is 32.8 percentage points above it, and the stated range ends above it.
By their numbers in this assay, from the lowest: compound 3; then compounds 2 and 1 (each within the scatter of the next).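

The aromatic carbon that carries this group is not a silent spot in this assay: nitro in place of ((butylcarbonyl)oxy)methyl gives a number 28.1 percentage points lower from compound 2 to compound 3 (beyond the scatter). The earlier pair could not show this, since those two compounds differ in more than one place and their numbers lie within the scatter of each other. The change takes the group from 8 heavy atoms to 3 while the counts of hydrogen-bond donors and acceptors stay the same, and no measurement at hand explains the step.

Going by these compounds, one swap changes both the size of the group and its kind, so it remains open whether the nitro group itself matters or the loss of the ester side chain is enough. An amine or a plain methyl on the same aromatic carbon would help to separate the two.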